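The source may hold more compounds than are shown below. What is called first, only, known or untested is meant among the compounds shown, and "the series" means these compounds.

Measured compounds:
Compound 1 `CCOC(=O)C1=C(C)NC(C)=C(C(=O)OCC)C1c1ccc(OCC(=O)NNC(=O)c2ccc(C)cc2)cc1`: 46.7%
Compound 2 `CCOC(=O)C1=C(C)NC(C)=C(C(=O)OCC)C1c1ccc(OCC(=O)NNC(=O)c2ccsc2Cl)cc1`: 52.8%

In a functional assay on the whole organism (strain Wistar) for inhibition, with Rattus norvegicus as the target, read by paw edema, with stated times of 30 min and 2 h, at a dose of 20 mg/kg (a higher number here means more inhibition at the dose given (going by the name of the read-out), a lower number less inhibition), compound 1 gives 46.7%, the smaller of the two numbers shown, while compound 2 gives 52.8%; the gap a number 6.1 percentage points higher from compound 1 to compound 2 (within the scatter) lies within the scatter. Compound 3 `CCOC(=O)C1=C(C)NC(C)=C(C(=O)OCC)C1c1ccc(OCC(=O)NN2C(=O)c3ccccc3C2=O)cc1` differs from compound 1 at a different place: a group of 11 heavy atoms (8 carbon, 1 nitrogen, 2 oxygen; one five-membered non-aromatic ring with 1 hetero atom, one six-membered aromatic ring of carbon only) in place of a group of 10 heavy atoms (8 carbon, 1 nitrogen, 1 oxygen; one six-membered aromatic ring of carbon only), on an amide-type nitrogen. Among the compounds with values here, the single measured step swaps the group on the carbonyl carbon, not the group on the amide-type nitrogen, so it bears on this change only as a sign that variation in this region left this assay nearly unchanged. Compound 3 is therefore expected to show a number 1.7 percentage points lower from compound 1 to compound 3 (within the scatter), nothing beyond the scatter. Compound 3 is estimated at 45%, within 30% to 60%.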

Compound 3, a percentage reported as inhibition, in the whole organism at one dose (the size of the read-out at that dose, not a potency): 57.2%
Compound 3: the middle estimate sits 12.2 percentage points below what was measured; the range from low to high includes it.
By their numbers in this assay, from the lowest: compounds 1, 2 and 3 (each within the scatter of the next, the first and the last beyond it).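

In this assay, within the data shown here, the ring-closed group on the amide-type nitrogen gives a number 10.5 percentage points higher from compound 1 to compound 3 (beyond the scatter) in place of ((4-methylphenyl)carbonyl)amino, the first step here to pass the scatter, so this position does affect the read-out. Against the 2-chlorothiophene compound, the same group gives a number 4.4 percentage points higher from compound 2 to compound 3 (within the scatter) and stands clear of compound 1 alone. Nothing available explains the step.

Open, from the compounds shown here alone, is whether a free amine or a simple acetyl group on that nitrogen would keep this value. Also open, going by these compounds, is whether the step holds at other doses.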